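Series notes: replacing the iodinated ring in compound 1

This account rests on a few compounds, and the source may have more. Where it says the series, first, only, none or still open, it means among the compounds named here.

The set is followed in an assay on cells for agonist activity at ecdysone receptor (Bombyx mori), read by a luciferase reporter, with a stated time of 24 h; a lower number here means that less compound is needed, a higher number that more compound is needed for the effect. Compound 1 `CC(C)(C)N(NC(=O)c1ccccc1)C(=O)c1ccccc1I` gives 105 nM, the lowest of the three numbers recorded. Compound 2 `CC(C)(C)N(NC(=O)c1ccccc1Cl)C(=O)c1ccccc1Cl` gives 331 nM, and compound 3 `CC(C)(C)N(NC(=O)c1ccccc1I)C(=O)c1ccccc1Cl` gives 1290 nM; compound 1 stands nearest to compound 2 and furthest from compound 3. Within the data shown here, the one single-site step among the measured compounds is a 3.9-fold higher number from compound 2 to compound 3 (0.59 log units; beyond the scatter), which shows that a change on the ring bearing the halogen is felt in this assay.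

Compound 4 `CC(C)(C)N(NC(=O)c1ccccc1)C(=O)C1CCCCC1` is not yet measured. It differs from compound 1 by cyclohexyl in place of 2-iodophenyl on a carbonyl carbon. Among the measured compounds shown here, no measured step exchanges the whole ring, so nothing among the recorded compounds bears directly on this change; the step from compound 2 to compound 3 only touches the substituent on that ring, not the ring itself. Because compound 1 gives 105 nM while carrying the iodinated aromatic ring, the best number of the set, exchanging that ring for cyclohexyl is expected to raise the number. The estimate for compound 4 is therefore a step of a 9.5-fold higher number from compound 1 to compound 4 (0.98 log units; beyond the scatter), with a wide range given the absence of a comparable measured step. Compound 4 is expected to give about 1000 nM, between 200 nM and 5000 nM.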

Compound 4, half-maximal effective concentration: 46800 nM
The estimate for compound 4 lay 47-fold (1.67 log units) below the measured number, outside the stated range (above it).
By their numbers in this assay, from the lowest: compound 1; then compound 2; then compound 3; then compound 4.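

Working notes on the result: in this assay, a six-membered carbon ring on this carbonyl carbon is not enough to hold the number near that of compound 1, as the exchange of 2-iodophenyl for cyclohexyl shows (a 450-fold higher number from compound 1 to compound 4 (2.65 log units; beyond the scatter)). Among these compounds, this large step concerns the whole group on the carbonyl carbon, whereas the only earlier step, a halogen exchange on an aromatic carbon (a 3.9-fold higher number from compound 2 to compound 3 (0.59 log units; beyond the scatter)), left every ring aromatic and gave no reading on a non-aromatic ring. The series therefore tolerates this change poorly, although the entering group differs from the leaving one only by the absence of iodine and of aromaticity in the ring. No measurement available here bears on the reason for this result.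

Among the compounds shown here, the single step changes both features at once, so it remains open whether the rise in the number follows the loss of the iodine or the loss of the aromatic ring. An unsubstituted phenyl, a 2-methylphenyl or a 2-iodocyclohexyl group on this carbonyl carbon would separate the two, and a pyridine ring would extend the comparison to a ring that is not of carbon only.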